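Swapping the amide aryl group for an amine chain

A few compounds are considered here, and "the series" means these few. Any claim that something is new, unique, unknown or untested is made for them only; others in the source may bear on it.

Of the compounds shown here, three sharing one core have been tested in an assay on isolated protein for inhibition of glutathione S-transferase Mu 2 (Homo sapiens), with a stated time of 10 min; a higher number here means a weaker inhibitor, a lower number a stronger inhibitor. Compound 1 `O=C(CCC(=O)OCCCCCCSc1ccc([N+](=O)[O-])c2nonc12)Nc1ccccc1F` gives 350 nM, compound 2 `COc1ccccc1NC(=O)CCC(=O)OCCCCCCSc1ccc([N+](=O)[O-])c2nonc12` gives 280 nM, and compound 3 `O=C(CCC(=O)OCCCCCCSc1ccc([N+](=O)[O-])c2nonc12)Nc1ccc(Br)cc1` gives 32000 nM, the highest of the three numbers. The next compound, compound 4 `CCN(CC)CCCNC(=O)CCC(=O)OCCCCCCSc1ccc([N+](=O)[O-])c2nonc12`, differs from compound 3 in one place: 3-(diethylamino)propyl in place of 4-bromophenyl on an amide-type nitrogen. From the compounds shown here alone, the two measured steps that touch this amide nitrogen, a 91-fold higher number from compound 1 to compound 3 (1.96 log units; beyond the scatter) and a 110-fold higher number from compound 2 to compound 3 (2.06 log units; beyond the scatter), show that what sits there moves the number strongly, yet neither involves a chain of this kind, so the direction for compound 4 remains open. With wide uncertainty, compound 4 is estimated at 4000 nM, between 400 nM and 40000 nM, which would mean an expected 8.0-fold lower number from compound 3 to compound 4 (0.90 log units; beyond the scatter).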

Compound 4, half-maximal inhibitory concentration: 440 nM
Beside the measured number, compound 4's estimate is 9.1-fold (0.96 log units) above it, within the range that was stated.
By their numbers in this assay, from the lowest: compounds 2, 1 and 4 (each within the scatter of the next); then compound 3.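

An aromatic ring on this amide nitrogen is not needed for a low number: the ring-free 3-(diethylamino)propyl chain brings a large fall from the 4-bromophenyl compound (a 73-fold lower number from compound 3 to compound 4 (1.86 log units; beyond the scatter)). The chain also stays level with both ring-bearing groups that give low numbers (a 1.6-fold higher number from compound 2 to compound 4 (0.20 log units; within the scatter); a 1.3-fold higher number from compound 1 to compound 4 (0.10 log units; within the scatter)), so among these four compounds only 4-bromophenyl stands apart. No supporting evidence explains this result.

A plain butyl chain or a 2-(diethylamino)ethyl chain would test whether the amine or the chain length matters. A 2-bromophenyl group would test whether bromine itself raises the number.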